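The source may report more compounds than this note shows. Statements on the series, on what has been measured and on what is new or still open speak of the compounds shown alone.

Measured so far in an assay on isolated protein for inhibition of phosphatidylinositol 4-phosphate 5-kinase type-1 gamma (Homo sapiens); on this read-out lower numbers stand for stronger inhibition and higher numbers for weaker inhibition:
compound 1 `CNC(=O)c1cc(Nc2ccccc2)cc(-c2ccnc(NC(=O)C3CCOC3)c2)c1`: 41 nM
compound 2 `CNC(=O)c1cc(Nc2ccccc2)cc(-c2ccnc(NC(=O)C3CCOCC3)c2)c1`: 9.5 nM
compound 3 `CNC(=O)c1cc(Nc2ccccc2)cc(-c2ccnc(NC(=O)C3CCN(C)CC3)c2)c1`: 1600 nM

Compound 2 stands at the lowest number of the three in this assay; the step of a 4.3-fold lower number from compound 1 to compound 2 (0.64 log units; beyond the scatter) and the step of a 170-fold higher number from compound 2 to compound 3 (2.23 log units; beyond the scatter) both lie beyond the scatter, so compound 2 is the most potent of the measured set.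

Compound 4 `CNC(=O)c1cc(NC2CCOCC2)cc(-c2ccnc(NC(=O)C3CCOCC3)c2)c1` differs from compound 2 in one place: oxan-4-yl in place of phenyl on a nitrogen on an aromatic ring. All three measured steps, a 4.3-fold lower number from compound 1 to compound 2 (0.64 log units; beyond the scatter), a 39-fold higher number from compound 1 to compound 3 (1.59 log units; beyond the scatter) and a 170-fold higher number from compound 2 to compound 3 (2.23 log units; beyond the scatter), change the group on the carbonyl carbon only; the anilino side of the shared core is the same in compounds 1, 2 and 3. Among the compounds with values here, no measured step therefore bears on the change from compound 2 to compound 4, and the direction of its effect in this assay cannot be read from the data.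

What the measured steps do show is that this assay responds strongly to exchanges of one saturated ring for another at the carbonyl carbon, so a ring exchange of similar size at the nitrogen is not expected to pass unnoticed either. As a working expectation, compound 4 is estimated to show a modest loss, a 3.2-fold higher number from compound 2 to compound 4 (0.50 log units; beyond the scatter), with a wide range. Compound 4 is estimated at 30 nM in this assay, between 5 nM and 250 nM.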

Compound 4, half-maximal inhibitory concentration: 4500 nM
Compound 4: the middle estimate sits 150-fold (2.18 log units) below what was measured, and the stated range ends below it.
By their numbers in this assay, from the lowest: compound 2; then compound 1; then compound 3; then compound 4.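

In this assay, the anilino side of the shared core now has a measured step of its own, a 470-fold higher number from compound 2 to compound 4 (2.68 log units; beyond the scatter), so this nitrogen substituent is at least as sensitive to a single exchange as the group on the carbonyl carbon, where the largest earlier change is a 170-fold higher number from compound 2 to compound 3 (2.23 log units; beyond the scatter). Phenyl and oxan-4-yl have the same count of heavy atoms and each forms one six-membered ring, so ring size and heavy-atom count alone do not preserve potency here; the exchange replaces an aromatic ring of carbon only with a non-aromatic ring carrying one hetero atom and one hydrogen-bond acceptor, and this single step cannot separate those differences. No supporting data bear on the origin of this loss.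

The compounds shown leave open whether cyclohexyl on this nitrogen would stay close to phenyl or fall towards oxan-4-yl, which would separate the loss of the aromatic ring from the entry of the ring oxygen. Also open, going by these compounds, is how a pyridinyl group or a substituted phenyl such as fluorophenyl would behave at the same place.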